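Shortening a Propyl Chain on a Shared Core

The compounds below may be only part of what the source reports. "The series", "measured", "known", "first", "only" and "open" are said of these compounds alone.

Compound 1, `CCCc1c(OC)nc2nc(C(=O)c3ccccc3)cn2c1CC`, is one of three related compounds tested in a functional assay on the whole organism with Rattus norvegicus as the target; a lower number here means that less compound is needed, a higher number that more compound is needed for the effect. In this assay compound 1 gives 10 mg/kg. Compound 2, `CCCc1c(SC)nc2nc(C(=O)c3ccccc3)cn2c1CC`, carries methylsulfanyl in place of methoxy on an aromatic carbon, and compound 2 gives 10 mg/kg. That step is no change at the digits printed from compound 1 to compound 2 (within the scatter). Compound 3, `CCCc1c(OC)nc2nc(C(=O)c3ccccc3)cn2c1C`, has hydrogen in place of methyl on a saturated chain carbon bound to an aromatic carbon, and compound 3 gives 5 mg/kg. That step is a 2.0-fold lower number from compound 1 to compound 3 (0.30 log units; within the scatter), too small to count as a real difference. Compound 1 therefore stands level with compound 2 at the highest of the three numbers, with compound 3 no further away than the scatter.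

The unmeasured compound 4, `CCc1c(OC)nc2nc(C(=O)c3ccccc3)cn2c1CC`, differs from compound 1 in one place: hydrogen in place of methyl on a saturated chain carbon, two bonds along the chain from an aromatic carbon. The closest comparison is the step from compound 1 to compound 3, which also took away a methyl from a saturated chain carbon, there bound to an aromatic carbon, and moved the number only within the scatter. Taking away a methyl on a saturated chain carbon two bonds along the chain from an aromatic carbon is expected to behave in the same way, so for compound 4 the expected step is a 1.4-fold lower number from compound 1 to compound 4 (0.15 log units; within the scatter), nothing beyond the scatter. The estimated value for compound 4 is 7 mg/kg, with a range from 3 mg/kg to 20 mg/kg.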

Compound 4, minimum effective dose: 2 mg/kg
Estimate against measurement, compound 4: 3.5-fold (0.54 log units) above, outside the stated range (below it).
By their numbers in this assay, from the lowest: compound 4; then compounds 3, 1 and 2 (each within the scatter of the next).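

For the compounds shown here, replacing the propyl chain of compound 1 with an ethyl chain is the only single change here that moves the number beyond the scatter: in this assay the step is a 5.0-fold lower number from compound 1 to compound 4 (0.70 log units; beyond the scatter). The effect is modest, but it shows that the chain carbon two bonds along from an aromatic carbon is sensitive to this change, whereas losing a methyl from the saturated chain carbon bound to an aromatic carbon gave only a 2.0-fold lower number from compound 1 to compound 3 (0.30 log units; within the scatter), so the same swap of hydrogen for methyl cannot simply be carried from one chain to the other. No measurement is available that would explain the difference between these two steps.

The compounds shown leave open whether the number would keep falling with a still shorter group, such as a methyl in place of the propyl chain, or would rise again with a longer chain such as butyl. They also leave open whether methylsulfanyl in place of methoxy, a step within the scatter on compound 1, would stay within it on compound 4.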